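Thromboxane synthase series: aryloxy variation at the dioxane side chain

The compounds below may be only part of what the source reports. "The series", "measured", "known", "first", "only" and "open" are said of these compounds alone.

Measured compounds:
compound 1, `N#Cc1ccccc1C1OCC(C/C=C\CCC(=O)O)C(c2cccnc2)O1`: 54 nM
compound 2, `CC(C)(C)c1ccc(OC(C)(C)C2OCC(C/C=C\CCC(=O)O)C(c3cccnc3)O2)cc1`: 280 nM

Of the compounds shown here, two on the shared core have been measured in an assay for inhibition of Thromboxane-A synthase (Homo sapiens), using microsomes; a higher number here means a weaker inhibitor, a lower number a stronger inhibitor. Compound 1 gives 54 nM in this assay. Compound 2 gives 280 nM in this assay, the higher of the two numbers; its gap to compound 1 lies beyond the usual scatter, so compound 2 is the weaker of the pair as measured. For the measured compounds named here, no single-point step between measured compounds is available, so nothing quantifies the effect of changing the aromatic group on the oxygen.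

Compound 3, `CC(C)(Oc1ccc(F)cc1[N+](=O)[O-])C1OCC(C/C=C\CCC(=O)O)C(c2cccnc2)O1`, is the next compound to be measured in this assay. It differs from compound 2 in one place: 4-fluoro-2-nitrophenyl in place of 4-(tert-butyl)phenyl on an oxygen on a saturated carbon. Going by the values given here, compound 2 is the only direct reference, and no measured step covers this exchange, so the expectation rests on compound 2 alone.

A moderate step toward a lower number is expected for compound 3, a 1.9-fold lower number from compound 2 to compound 3 (0.27 log units; within the scatter), but the direction is uncertain and a result within the scatter of compound 2 would not surprise. For compound 3 the estimate in this assay is 150 nM, with a range from 40 nM to 600 nM.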

Compound 3, half-maximal inhibitory concentration: 20 nM
For compound 3 the middle estimate is 7.5-fold (0.88 log units) above the measured one; measured number below the stated range.
By their numbers in this assay, from the lowest: compound 3; then compound 1; then compound 2.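

In this assay, for the compounds shown here, exchanging 4-(tert-butyl)phenyl for 4-fluoro-2-nitrophenyl on the oxygen on a saturated carbon gives a 14-fold lower number from compound 2 to compound 3 (1.15 log units; beyond the scatter), the first single-place step, and it shows that the number responds strongly to the group at this position. The groups match in heavy-atom count and each has one six-membered aromatic ring of carbon only, so this step cannot be read as a matter of group size by that count; what differs is the set of atoms on the ring, with the tert-butyl group leaving and the fluorine and nitro group entering. No measurement at hand bears on why the step is this large.

The fluorine and the nitro group enter together in this one step, so the compounds shown do not tell what each contributes alone. Going by these compounds, it also stays open whether a ring carrying a methoxy group or an amine in place of the nitro group would keep the number near that of compound 3 at 20 nM.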